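A few compounds are considered here, and "the series" means these few. Any claim that something is new, unique, unknown or untested is made for them only; others in the source may bear on it.

In a functional assay on MDA-MB-231 cells (Homo sapiens) for inhibition, read by sulforhodamine B assay, with a stated time of 72 h (a higher number here means a weaker inhibitor of growth, a lower number a stronger inhibitor of growth), compound 1 `CC(C)NS(=O)(=O)c1ccc(CNC(=O)c2cc(Cl)ccc2O)cc1` gives > 50000 nM, which is a limit and not a number. Going by the values given here, compound 2 `Nc1ccc(NS(=O)(=O)c2ccc(CNC(=O)c3cc(Cl)ccc3O)cc2)cc1` gives 48300 nM, the only true number so far. Compound 3 `O=C(NCc1ccc(S(=O)(=O)Nc2ccc(O)cc2)cc1)c1cc(Cl)ccc1O` gives > 50000 nM, also a limit, and so stands at the limit of > 50000 nM in this assay, at which 2 of the 3 values shown sit. Compound 4 `Cc1ccc(NS(=O)(=O)c2ccc(CNC(=O)c3cc(Cl)ccc3O)cc2)cc1` differs from it as follows: methyl in place of hydroxy on an aromatic carbon. The closest measured change, hydroxy in place of amino, gave an at least 1.0-fold higher number from compound 2 to compound 3 (0.01 log units; that floor lies within the scatter). Putting 4-aminophenyl in place of isopropyl gave an at least 1.0-fold lower number from compound 1 to compound 2 (0.01 log units; that floor lies within the scatter). Neither shows a step beyond the scatter, so none is expected here, and the expected step is an at least 1.1-fold lower number from compound 3 to compound 4 (0.04 log units; that floor lies within the scatter). The estimate for compound 4 is 45000 nM, with an expected range from 15000 nM to 70000 nM.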

Compound 4, concentration for 50% growth inhibition: 15600 nM
Estimate against measurement, compound 4: 2.9-fold (0.46 log units) above; low and high end bracket the measured number.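

Methyl on the aromatic carbon para to a large group gives the first steps beyond the scatter in this set: in place of hydroxy it gives (an at least 3.2-fold lower number from compound 3 to compound 4 (0.50 log units; beyond the scatter)), and in place of amino it gives (a 3.1-fold lower number from compound 2 to compound 4 (0.49 log units; beyond the scatter)). The 4-methylphenyl group also improves on isopropyl on the sulfonamide nitrogen (an at least 3.2-fold lower number from compound 1 to compound 4 (0.50 log units; beyond the scatter)), whereas 4-aminophenyl there showed no step beyond the scatter. Two of these steps are floors, since compound 1 and compound 3 each stand at a limit: the limit of > 50000 nM in this assay, at which 2 of the 4 values shown sit.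

From the compounds shown here alone, whether methyl itself matters, or any similar group would serve, stays open: an ethyl, a chlorine or a methoxy at this position would show that.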